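The source may hold more compounds than are shown below. What is called first, only, known or untested is meant among the compounds shown, and "the series" means these compounds.

Measured so far in an assay on CHO cells for displacement of a labelled ligand from adenosine receptor A3 (Homo sapiens), read by scintillation counting, with a stated time of 120 min, tested at 10 uM; on this read-out lower numbers stand for less inhibition and higher numbers for more inhibition at the one concentration tested (going by the name of the read-out):
compound 1, `Nc1scc(CN2CCN(c3cccc(Cl)c3Cl)CC2)c1C(=O)c1ccc(Cl)cc1`: 0%
compound 2, `Nc1scc(CN2CCN(c3ccc(F)cc3Cl)CC2)c1C(=O)c1ccc(Cl)cc1`: 0%
compound 3, `Nc1scc(CN2CCN(c3ccc([N+](=O)[O-])cc3)CC2)c1C(=O)c1ccc(Cl)cc1`: 2%

Compound 1 stands level with compound 2 at the digits printed, the two together the lowest of the three numbers. Its nearest neighbour is compound 2, with no change at the digits printed from compound 1 to compound 2 (within the scatter); its furthest is compound 3, with a number 2 percentage points higher from compound 1 to compound 3 (within the scatter). The remaining pair shows a number 2 percentage points higher from compound 2 to compound 3 (within the scatter). All three values thus sit together at the bottom of the read-out, with no step beyond the scatter among them.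

Compound 4, `Nc1scc(CN2CCN(c3cccc4ccccc34)CC2)c1C(=O)c1ccc(Cl)cc1`, is not yet measured. It differs from compound 1 as follows: naphthalen-1-yl in place of 2,3-dichlorophenyl on an amine nitrogen in a ring. The measured steps that bear on this change are the three in which the group on the same ring nitrogen was exchanged: no change at the digits printed from compound 1 to compound 2 (within the scatter), a number 2 percentage points higher from compound 1 to compound 3 (within the scatter) and a number 2 percentage points higher from compound 2 to compound 3 (within the scatter). Each exchange left the read-out within the scatter, whatever group was brought in, and nothing among them singles out naphthalen-1-yl. The expectation for compound 4 is therefore a step of a number 3 percentage points higher from compound 1 to compound 4 (within the scatter), none beyond the scatter. Compound 4 is estimated at 3% in this assay, with a range from -7% to 15%.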

Compound 4, a percentage reported as inhibition, at one concentration (the size of the read-out at that concentration, not a potency): 0%
Compound 4: the middle estimate sits 3 percentage points above what was measured; the range from low to high includes it.
By their numbers in this assay, from the lowest: compounds 1, 2, 4 and 3 (each within the scatter of the next).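

Naphthalen-1-yl on the amine nitrogen brings a second six-membered aromatic ring of carbon only and no chlorine, and in this assay the steps read no change at the digits printed from compound 1 to compound 4 (within the scatter) and no change at the digits printed from compound 2 to compound 4 (within the scatter) and a number 2 percentage points lower from compound 3 to compound 4 (within the scatter). The earlier compounds shown here varied only the groups on a single phenyl ring, so the new information is that changing the ring count at this place and removing every halogen also leaves all four numbers within the scatter of one another, with no compound going against this. No supporting data bear on why the read-out stays this flat across the four groups.

All four compounds share the same core and carry an aromatic ring directly on the ring nitrogen, so this set cannot tell whether any group at this place can lift the read-out clear of the bottom of its range. Open, from the compounds shown here alone, are a benzyl group, a longer chain ending in an amine or a carboxylic acid on that nitrogen, and any change to the shared core itself.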